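This account rests on a few compounds, and the source may have more. Where it says the series, first, only, none or still open, it means among the compounds named here.

Compound 1 `COc1ccc(Cn2cc3cc(C(=N)Nc4ccc(N5CCN(C)CC5)cc4)ncc3n2)cc1` is one of two compounds with a measurement in a functional assay on PC-3 cells (Homo sapiens) for cytotoxicity, read by MTT assay, with a stated time of 72 h; a lower number here means a stronger inhibitor, a higher number a weaker inhibitor. In this assay compound 1 gives 9900 nM, the lower of the two numbers shown. Compound 2 `N=C(Nc1cccc(C(F)(F)F)c1)c1cc2c(-c3ccccc3)n[nH]c2cn1` carries a different substitution pattern on the shared core and, in this assay, compound 2 gives 19900 nM; the gap between these two values lies within the usual scatter, so no order between them can be read from the data.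

Compound 3 `CN1CCN(c2ccc(NC(=N)c3cc4cn(C)nc4cn3)cc2)CC1` has not yet been measured. It differs from compound 1 in a single place: hydrogen in place of 4-methoxyphenyl on a saturated chain carbon bound to an aromatic nitrogen. Cut one bond further out, the same change reads 4-methoxybenzyl to methyl.

Going by the values given here, no step between measured compounds is available to anchor the size of such a change. Both measured values sit in the same weak range, and the remainder of compound 1, including the amidine and the methylpiperazinyl-phenyl group, is kept in compound 3. The step from compound 1 to compound 3 is therefore expected to be small, a 1.3-fold higher number from compound 1 to compound 3 (0.12 log units; within the scatter), if anything toward a weaker number, and it may well lie within the scatter. For compound 3 in this assay the estimate is 13000 nM, with a range from 4500 nM to 40000 nM.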

Compound 3, half-maximal inhibitory concentration: 24800 nM
Compound 3: the middle estimate sits 1.9-fold (0.28 log units) below what was measured; the range from low to high includes it.
By their numbers in this assay, from the lowest: compounds 1, 2 and 3 (each within the scatter of the next, the first and the last beyond it).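

In this assay, going by these compounds alone, compounds 1 and 3 give the first comparison that differs in one place only. Putting hydrogen in place of 4-methoxyphenyl on a saturated chain carbon bound to an aromatic nitrogen, which reads as 4-methoxybenzyl to methyl when cut one bond further out, gives a 2.5-fold higher number from compound 1 to compound 3 (0.40 log units; beyond the scatter), a modest step but one beyond the scatter, so this position does register in the read-out, while the loss of the whole 4-methoxyphenyl group still leaves compound 3 with a measurable number of 24800 nM in the same weak range. No measurement at hand bears on what lies behind this step.

The compounds shown leave open which part of the 4-methoxybenzyl group carries the difference, since a plain benzyl group, lacking the methoxy, would separate the aromatic ring from its substituent, and a longer chain such as propyl would show whether size alone at this place moves the number. They also leave open whether a group ending in an amine or a carboxylic acid at this place would shift the value in either direction, and whether the step would hold with other groups on the amidine nitrogen.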